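A few compounds are considered here, and "the series" means these few. Any claim that something is new, unique, unknown or untested is made for them only; others in the source may bear on it.

Compounds measured so far in a physicochemical assay for lipophilicity (a lower number here means a more polar compound, a higher number a more lipophilic compound), are these
- compound 1 `CC(=O)NCc1cccc(Cn2nc(NS(=O)(=O)c3ccc(Cl)s3)c3c(Cl)cccc32)c1` gives 3.8
- compound 2 `CC(=O)NCc1cccc(Cn2nc(NS(=O)(=O)c3ccc(Cl)s3)c3c(F)cccc32)c1` gives 3
- compound 3 `CC(=O)NCc1cccc(Cn2nc(NS(=O)(=O)c3ccc(Cl)s3)c3c(C#N)cccc32)c1` gives 2.5

Of these three, compound 3 stands lowest in this assay and its gaps to both others lie beyond the scatter. Compound 4 `CC(=O)NCc1cccc(Cn2nc(NS(=O)(=O)c3ccc(Cl)s3)c3c(C(C)(C)O)cccc32)c1` has not been measured yet. It carries 1-hydroxy-1-methylethyl in place of cyano on an aromatic carbon, and the change from compound 3 counts as 1-hydroxy-1-methylethyl in place of cyano on an aromatic carbon in full.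

Among the measured compounds shown here, two measured steps bear on this carbon, and both end at the cyano compound. The large one is a number 1.30 log units lower from compound 1 to compound 3 (beyond the scatter) and the modest one is a number 0.50 log units lower from compound 2 to compound 3 (beyond the scatter), so both other groups tested here give higher numbers than cyano. Neither step involves 1-hydroxy-1-methylethyl, so they offer only a loose guide. Leaving cyano is therefore expected to raise the number, by about the size of the modest step. The expected change is a number 0.50 log units higher from compound 3 to compound 4 (beyond the scatter) and it points upward. For compound 4 the estimated value is 3, with an expected range from 2.5 to 3.5 for the measurement still to come.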

Compound 4, distribution coefficient: 2.9
Compound 4: middle estimate off by 0.10 log units, on the high side; the measured number falls inside the stated range.
By their numbers in this assay, from the lowest: compound 3; then compounds 4 and 2 (each within the scatter of the next); then compound 1.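

In this assay, among the compounds shown here, 1-hydroxy-1-methylethyl is the first group on this aromatic carbon that brings a hydrogen-bond donor, and its number cannot be told apart from that of the fluoro compound (a number 0.10 log units lower from compound 2 to compound 4 (within the scatter)). It has more heavy atoms than cyano and than chloro, yet it sits on opposite sides of those two groups (a number 0.40 log units higher from compound 3 to compound 4 (beyond the scatter); a number 0.90 log units lower from compound 1 to compound 4 (beyond the scatter)), so across these four compounds the number does not simply follow the count of heavy atoms in the group. No measurement shown explains why each group falls where it does. Still open, on these data alone, is how isopropyl, which has the same carbon skeleton without the hydroxyl, would compare on this carbon. An amine or a carboxylic acid there is equally untested in the compounds shown.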